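The compounds below may be only part of what the source reports. "The series", "measured", "known", "first", "only" and "open" are said of these compounds alone.

In an ADME assay on microsomes (Mus musculus) for metabolic stability, read by LC-MS, using NADPH, with a stated time of 1 h, tested at 1 uM (a lower number here means slower removal, a higher number faster removal of the compound), compound 3 `CC(=O)Nc1cccc(Cn2cc(-c3ccc4c(N)n[nH]c4c3)ccc2=O)c1` stands at 14 mL.min-1.g-1, the lower of the two values that are actual numbers. Compound 2 `O=c1ccc(-c2ccc3cn[nH]c3c2)cn1Cc1cccc(C(F)(F)F)c1` gives 63 mL.min-1.g-1, and its gap to compound 3 lies beyond the scatter. Compound 1 `Nc1n[nH]c2cc(-c3ccc(=O)n(Cc4cccc(Cl)c4)c3)ccc12` gives < 10 mL.min-1.g-1, which is a limit of the assay and not a number.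

Compound 4 `Nc1n[nH]c2cc(-c3ccc(=O)n(Cc4cccc(C(F)(F)F)c4)c3)ccc12` differs from compound 3 by trifluoromethyl in place of acetamido on an aromatic carbon. The closest measured step is an at least 1.4-fold higher number from compound 1 to compound 3 (0.14 log units; that floor lies within the scatter), where acetamido replaces chloro, and it rests on (the limit of < 10 mL.min-1.g-1 in this assay, at which 1 of the 3 values shown sits). Its floor lies within the scatter, so it gives no firm size. Compound 2 also carries trifluoromethyl, but on a different core, so its value of 63 mL.min-1.g-1 does not transfer directly. No step beyond the scatter is therefore expected in this assay, and no firm direction is expected either. The expected change is a 1.1-fold higher number from compound 3 to compound 4 (0.03 log units; within the scatter). Compound 4 is estimated at 15 mL.min-1.g-1, with an expected range from 7 mL.min-1.g-1 to 35 mL.min-1.g-1.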

Compound 4, intrinsic clearance in microsomes: < 10 mL.min-1.g-1
Compound 4 was reported as a limit; the forecaster's own chance of this, stated with the estimate: 30%; middle value at least 1.5-fold (0.17 log units) away from the limit.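

In this assay, among the compounds shown here, an at least 6.3-fold lower number from compound 2 to compound 4 (0.79 log units; beyond the scatter): this gives the first one-place reading of amino in place of hydrogen on an aromatic carbon, with trifluoromethyl held constant. At the position meta to a large group, trifluoromethyl in place of acetamido gives an at least 1.4-fold lower number from compound 3 to compound 4 (0.14 log units; that floor lies within the scatter), so this change has no firm size or direction yet. Compound 4 is reported as a limit and compound 1 as well, so the step between them cannot be read: the limit of < 10 mL.min-1.g-1 in this assay, at which 2 of the 4 values shown sit.

Any separation among chloro, trifluoromethyl and acetamido at this position therefore remains open, as does the size of the amino step, of which only a floor is available. From the compounds shown here alone, how a carboxylic acid or an amine on the same aromatic carbon would read in this assay also remains open.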